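The compounds below may be only part of what the source reports. "The series", "measured", "known", "first", "only" and "open" are said of these compounds alone.

Measured so far: compound 1, `CN(C)CCNc1ccnc2cc(OCc3ccccc3)ccc12`, gives 2140 nM in a functional assay on DLD-1 cells (Homo sapiens) for cytotoxicity, read by MTT assay, with a stated time of 48 h; a lower number here means a stronger inhibitor, a higher number a weaker inhibitor; compound 2, `C=CCOc1ccc2c(NCCN(C)C)ccnc2c1`, gives 1530 nM in this assay.

Compound 2 holds the lower of these two numbers, yet only by a 1.4-fold lower number from compound 1 to compound 2 (0.15 log units; within the scatter), which lies within the scatter. Compound 3, `CCCCCCOc1ccc2c(NCCN(C)C)ccnc2c1`, is still unmeasured and differs from compound 2 by pentyl in place of vinyl on a saturated chain carbon bound to an oxygen on an aromatic ring. For the measured compounds named here, the one measured step, a 1.4-fold lower number from compound 1 to compound 2 (0.15 log units; within the scatter), also exchanged the group at this place and stayed within the scatter, so no change beyond the scatter is expected here either. Compound 3 is therefore expected near 1500 nM, within 600 nM to 4000 nM, an expected step of a 1.0-fold lower number from compound 2 to compound 3 (0.01 log units; within the scatter).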

Compound 3, half-maximal inhibitory concentration: 1870 nM
Compound 3: the middle estimate sits 1.2-fold (0.10 log units) below what was measured; the measured number falls inside the stated range.
By their numbers in this assay, from the lowest: compounds 2, 3 and 1 (each within the scatter of the next).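

Replacing vinyl with pentyl gives a 1.2-fold higher number from compound 2 to compound 3 (0.09 log units; within the scatter), and replacing phenyl with pentyl gives a 1.1-fold lower number from compound 1 to compound 3 (0.06 log units; within the scatter). For the compounds shown here, this is the first compound with a fully saturated chain at this place, with neither a ring nor a double bond outside aromatic rings in the group that enters. Among these three compounds, therefore, a phenyl, vinyl or pentyl group on this carbon makes no difference beyond the scatter. No supporting measurement explains this sameness. Still open, from the compounds shown here alone, is whether an amine, a carboxylic acid or a chain longer than hexyloxy at this place would move the number beyond the scatter.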